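Swapping the sulfur substituent in the sulfanyl compounds

The compounds below may be only part of what the source reports. "The series", "measured", "known", "first", "only" and "open" are said of these compounds alone.

In a functional assay on DU-145 cells (Homo sapiens) for inhibition, read by trypan blue exclusion, with a stated time of 96 h (a higher number here means a weaker inhibitor of growth, a lower number a stronger inhibitor of growth), compound 3 (`Cc1ccc(S/C(=C/c2ccc(Oc3ccccc3)cc2)C(=O)c2ccc(Cl)cc2)cc1`) gives 10000 nM and lies within the scatter of compound 1 (`O=C(/C(=C\c1ccc(Cl)cc1)SCc1ccccc1Cl)c1ccc(Cl)cc1`) at 12000 nM among the three measured numbers. Compound 2 (`Cc1ccc(S(=O)(=O)/C(=C/c2ccc(Oc3ccccc3)cc2)C(=O)c2ccc(Cl)cc2)cc1`) stands clearly lower at 1000 nM in the same test. Among the measured compounds shown here, the only measured step is a 10-fold higher number from compound 2 to compound 3 (1.00 log units; beyond the scatter) and it exchanges sulfonyl for sulfanyl, a change not repeated here, so it gives no direct guide to the next step.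

Compound 4 (`O=C(/C(=C\c1ccc(Oc2ccccc2)cc1)SCc1ccccc1Cl)c1ccc(Cl)cc1`) keeps the sulfanyl link and differs from compound 3 by 2-chlorobenzyl in place of 4-methylphenyl on a sulfur. For the measured compounds named here, no measured step covers this exchange. The nearest evidence is compound 1, which carries the same 2-chlorobenzyl on a sulfur, differs elsewhere as well, and gives 12000 nM in the same range as compound 3. In this assay the expected step is a 1.1-fold higher number from compound 3 to compound 4 (0.04 log units; within the scatter) and so none beyond the scatter. Compound 4 is estimated at 11000 nM with 4000 nM to 25000 nM as the expected range.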

Compound 4, concentration for 50% growth inhibition: 1000 nM
For compound 4 the middle estimate is 11-fold (1.04 log units) above the measured one; measured number below the stated range.
By their numbers in this assay, from the lowest: compounds 2 and 4 (each within the scatter of the next); then compounds 3 and 1 (each within the scatter of the next).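

In this assay the group on the sulfur matters: 2-chlorobenzyl in place of 4-methylphenyl gives a 10-fold lower number from compound 3 to compound 4 (1.00 log units; beyond the scatter) and shows that a sulfanyl link need not carry the higher number. Sulfonyl is not required for the lower number either, as (2-chlorobenzyl)sulfanyl in place of (4-methylphenyl)sulfonyl gives no change at the digits printed from compound 2 to compound 4 (within the scatter) and leaves the two compounds within the scatter. With 2-chlorobenzyl kept, phenoxy in place of chloro on an aromatic carbon gives a 12-fold lower number from compound 1 to compound 4 (1.08 log units; beyond the scatter) and shows that 2-chlorobenzyl alone does not secure the lower number.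

Still open, as far as these compounds go, is how a sulfonyl link bearing 2-chlorobenzyl would read, and whether an amine could stand in place of phenoxy. No evidence given here accounts for these steps.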